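The source may hold more compounds than are shown below. What is called first, only, known or untested is meant among the compounds shown, and "the series" means these compounds.

Working notes on the series. In an assay on isolated protein for binding affinity to Type-2 angiotensin II receptor (Homo sapiens) (a lower number here means a stronger inhibitor, a higher number a weaker inhibitor), compound 1 (`CCCc1nc(CC)c(C(=O)OCC(=O)c2ccccc2)n1Cc1ccc(-c2ccccc2S(=O)(=O)NC(=O)OCCC(C)C)cc1F`) gives 2 nM, the lowest of the three numbers in hand. Compound 2 (`CCCc1nc(CC)c(C(=O)OCc2ccccc2OCCC(C)C)n1Cc1ccc(-c2ccccc2S(=O)(=O)NC(=O)OCCC(C)C)cc1F`) gives 10 nM and compound 3 (`CCCc1nc(CC)c(C(=O)OC(C(=O)c2ccccc2)c2ccccc2)n1Cc1ccc(-c2ccccc2S(=O)(=O)NC(=O)OCCC(C)C)cc1F`) gives 3 nM. Of the two steps, a 5.0-fold higher number from compound 1 to compound 2 (0.70 log units; beyond the scatter), while a 1.5-fold higher number from compound 1 to compound 3 (0.18 log units; within the scatter). Compound 4 (`CCCc1nc(CC)c(C(=O)NCCCOc2ccccc2)n1Cc1ccc(-c2ccccc2S(=O)(=O)NC(=O)OCCC(C)C)cc1F`) differs from compound 1 by (3-phenoxypropyl)amino in place of benzoylmethoxy on a carbonyl carbon. Neither measured step covers an amide in place of an ester on that carbonyl carbon; both only rework the group on the ester, so the nearest guide is the weakening seen in the step from compound 1 to compound 2. A loss of that order is expected, giving a 3.5-fold higher number from compound 1 to compound 4 (0.54 log units; beyond the scatter). Compound 4 is therefore estimated at 7 nM, with a range from 2 nM to 25 nM in this assay.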

Compound 4, half-maximal inhibitory concentration: 9 nM
Beside the measured number, compound 4's estimate is 1.3-fold (0.11 log units) below it, and the stated range covers the measured number.
By their numbers in this assay, from the lowest: compounds 1 and 3 (each within the scatter of the next); then compounds 4 and 2 (each within the scatter of the next).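

In this assay the change to (3-phenoxypropyl)amino on this carbonyl carbon gives a 4.5-fold higher number from compound 1 to compound 4 (0.65 log units; beyond the scatter) and is the first step shown that replaces the ester oxygen, bringing in a nitrogen and 1 hydrogen-bond donor. The position therefore accepts an amide as well as an ester, with a loss beyond the scatter. No supporting data on the series bear on the reason for this loss.

The step changes the link and the chain together, leaving their separate contributions unresolved. Going by these compounds, how a carboxylic acid or a shorter chain such as methylamino would behave on this carbonyl carbon also remains open.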